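This account rests on a few compounds, and the source may have more. Where it says the series, first, only, none or still open, it means among the compounds named here.

Of the compounds shown here, three sharing a common core have so far been tested in an assay on isolated protein for inhibition of malate dehydrogenase, mitochondrial (Sus scrofa), with stated times of 45 min and 30 min; a lower number here means a stronger inhibitor, a higher number a weaker inhibitor. Compound 1 `COc1ccc(S(=O)(=O)Nc2ccc(-c3nc4ccccc4o3)cc2)cc1` gives in this assay only the limit > 63000 nM. Compound 3 `O=S(=O)(Nc1ccc(-c2nc3ccccc3o2)cc1)c1ccc(C(F)(F)F)cc1` likewise gives in this assay the limit > 63000 nM. Going by the values given here, the one step between measured compounds, a step that the two limits leave unreadable from compound 1 to compound 3, therefore cannot be read, because both of its ends sit at the limit of > 63000 nM in this assay, at which 3 of the 3 values shown sit. Compound 2 `Cc1ccccc1S(=O)(=O)Nc1ccc2oc(-c3ccccc3)nc2c1` stands at the same point: in this assay compound 2 gives the limit > 63000 nM. Compound 4 `O=S(=O)(Nc1ccc2oc(-c3ccccc3)nc2c1)c1ccc(Cl)cc1` has not yet been measured. It differs from compound 2 in one place, (4-chlorophenyl in place of 2-methylphenyl on a sulfonyl sulfur). Among the compounds with values here, no measured step bears directly on this change, since the only computed step concerns a different part of the structure and its size is unreadable; the whole of the evidence is that all three measured values rest at the limit of > 63000 nM in this assay, at which 3 of the 3 values shown sit. Nothing in these data gives reason to expect compound 4 to leave that limit, so the expected step that the limit leaves unreadable from compound 2 to compound 4 is none beyond the scatter. Compound 4 is therefore expected to give 100000 nM, with a range from 50000 nM to 300000 nM, and most likely to be reported only as a limit.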

Compound 4, half-maximal inhibitory concentration: > 63000 nM
Compound 4: a limit, no number (the forecaster's own chance of this, stated with the estimate: 85%); the middle value does not contradict the limit.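

Going by these compounds alone, compound 4, like compound 2, gives only a limit and no number in this assay, so no new step can be read between them, and the result adds only one more value at the same point: the limit of > 63000 nM in this assay, at which 4 of the 4 values shown sit.

The compounds shown leave open whether any change to the shared core would give a measurable value in this assay.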